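This account rests on a few compounds, and the source may have more. Where it says the series, first, only, none or still open, it means among the compounds named here.

Three compounds sharing one core have been examined in a toxicity assay on THP-1 cells (Homo sapiens) for inhibition; on this read-out lower numbers stand for higher toxicity in this test and higher numbers for lower toxicity in this test. Compound 1 carries a 2-fluorophenyl on its carbonyl carbon, `COc1ccc(-c2cnc(NC(=O)c3ccccc3F)n2C)cc1`. Compound 2 carries a 1H-pyrazol-5-yl at that place, `COc1ccc(-c2cnc(NC(=O)c3ccn[nH]3)n2C)cc1`, and compound 3 a phenethyl, `COc1ccc(-c2cnc(NC(=O)CCc3ccccc3)n2C)cc1`. In this assay compound 1 reaches only a limit, > 100000 nM. Compound 2 also gives only a limit, > 100000 nM. Compound 3 likewise stands at a limit, > 100000 nM. Hence none of the steps among them can be read: a step that the two limits leave unreadable from compound 1 to compound 3, a step that the two limits leave unreadable from compound 2 to compound 3 and a step that the two limits leave unreadable from compound 1 to compound 2 each lie between two limits. All three values sit at one place, (the limit of > 100000 nM in this assay, at which 3 of the 3 values shown sit).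

Compound 4, `CCCC(=O)Nc1ncc(-c2ccc(OC)cc2)n1C`, differs from compound 3 as follows: methyl in place of phenyl on a saturated chain carbon, two bonds along the chain from a carbonyl carbon. Within the data shown here, no measured step bears readably on this change, since the three steps between compounds 1, 2 and 3 are all unreadable. Because compound 3 gives > 100000 nM, and the other two compounds sit at the same point, the step that the limit leaves unreadable from compound 3 to compound 4 is expected to be none beyond the scatter. Compound 4 is therefore estimated at 150000 nM, within a range from 50000 nM to 500000 nM, most probably reported again as a limit.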

Compound 4, half-maximal cytotoxic concentration: > 100000 nM
Compound 4 gave a limit, no number (the forecaster's own chance of this, stated with the estimate: 85%); the middle value is on the limit's open side.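

In this assay, among these compounds, compound 4 gives only a limit, > 100000 nM, so no step from it to compound 1, compound 2 or compound 3 can be read. All the values shown now sit at one place: the limit of > 100000 nM in this assay, at which 4 of the 4 values shown sit.

The compounds shown leave open whether any group on the carbonyl carbon of the shared core would give a readable number in this assay.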